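Anilino versus benzylamino on a nitropyrimidine core

This account rests on a few compounds, and the source may have more. Where it says the series, first, only, none or still open, it means among the compounds named here.

Measured compounds:
- Compound 1 `CCOC(=O)CN(Cc1ccccc1)c1nc(NCc2cccc(OC)c2)ncc1[N+](=O)[O-]`: 80700 nM
- Compound 2 `CCOC(=O)CNc1nc(Nc2ccccc2)ncc1[N+](=O)[O-]`: 54300 nM
- Compound 3 `COC(=O)CN(C)c1nc(Nc2cccc(OC)c2)ncc1[N+](=O)[O-]`: 58000 nM

All three were run in a functional assay on MDA-MB-231 cells (Homo sapiens) for antiproliferative activity, read by MTT assay, with a stated time of 48 h; a lower number here means a stronger inhibitor, a higher number a weaker inhibitor. Within this set the number for compound 1 is the largest, yet its gaps to compound 3 and to compound 2 both lie within the usual scatter, so the three read as indistinguishable. Compound 2 and compound 3 carry an aryl group directly on the exocyclic nitrogen, while compound 1 carries a benzyl group there; the numbers give no sign that this matters.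

Compound 4 `CCOC(=O)CN(Cc1ccccc1)c1nc(Nc2ccc(Cl)cc2)ncc1[N+](=O)[O-]` has not yet been measured in this assay. It differs from compound 1 by 4-chlorophenyl in place of 3-methoxybenzyl on a nitrogen on an aromatic ring. Since compound 2 and compound 3, which already hold an aryl group on that nitrogen, sit within the scatter of compound 1, no step beyond the scatter is expected in either direction; the estimated step from compound 1 to compound 4 is a 1.3-fold lower number from compound 1 to compound 4 (0.13 log units; within the scatter). Compound 4 is therefore expected to give 60000 nM, with a range from 20000 nM to 150000 nM.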

Compound 4, half-maximal inhibitory concentration: 34400 nM
Beside the measured number, compound 4's estimate is 1.7-fold (0.24 log units) above it, within the range that was stated.
By their numbers in this assay, from the lowest: compounds 4, 2, 3 and 1 (each within the scatter of the next, the first and the last beyond it).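

Among these compounds, at this place, on a nitrogen on an aromatic ring, this assay gives the first step that can be told apart from the scatter: a 2.3-fold lower number from compound 1 to compound 4 (0.37 log units; beyond the scatter), a modest gain with 4-chlorophenyl in place of 3-methoxybenzyl. Among the compounds shown here, the earlier compounds offered no one-place comparison, so this pair is the first to show that the series responds to a change at this position, with the rest of compound 1 held constant. No measurement shown here accounts for the size or direction of this step.

Going by these compounds, the change replaces the ring, its substituent and the carbon link to the nitrogen together, so the part that carries the step stays open. Groups such as 4-chlorobenzyl or 4-methoxyphenyl at this place would separate those contributions, and whether the gain extends to a carboxylic acid in place of the ethyl ester also remains unknown.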